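This account rests on a few compounds, and the source may have more. Where it says the series, first, only, none or still open, it means among the compounds named here.

Compound 1 `COc1ccc(C(=O)c2cc(OC)c(OC)c(OC)c2)cc1NC(=O)/C=C/c1cccc(OC(F)(F)F)c1` gives 7900 nM in a functional assay on COLO 205 cells (Homo sapiens) for cytotoxicity, read by MTT assay, with a stated time of 72 h; on this read-out higher numbers stand for weaker inhibition and lower numbers for stronger inhibition. Compound 2 `COc1ccc(C(=O)c2cc(OC)c(OC)c(OC)c2)cc1NC(=O)/C=C/c1ccc(N)cc1` gives 10300 nM in this assay. Of the two numbers on hand, compound 2 carries the larger, yet the step of a 1.3-fold higher number from compound 1 to compound 2 (0.12 log units; within the scatter) lies within the scatter, so the two compounds cannot be told apart on these readings. Compound 3 `COc1ccc(C(=O)c2cc(OC)c(OC)c(OC)c2)cc1NC(=O)/C=C/c1ccc([N+](=O)[O-])cc1` differs from compound 2 by nitro in place of amino on an aromatic carbon, para to a large group. Among the compounds with values here, only one measured step touches the aryl end of the chain, a 1.3-fold higher number from compound 1 to compound 2 (0.12 log units; within the scatter), and it stayed within the scatter; no measured pair sets nitro against amino. Nothing in hand therefore points to a step beyond the scatter in this assay in either direction. For compound 3 the estimated value is 10000 nM, with a range from 4000 nM to 25000 nM, which means an expected step of a 1.0-fold lower number from compound 2 to compound 3 (0.01 log units; within the scatter).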

Compound 3, half-maximal inhibitory concentration: 11400 nM
Beside the measured number, compound 3's estimate is 1.1-fold (0.06 log units) below it; the range from low to high includes it.
By their numbers in this assay, from the lowest: compounds 1, 2 and 3 (each within the scatter of the next).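

In this assay, within the data shown here, nitro in place of amino on this aromatic carbon, para to a large group, gives a 1.1-fold higher number from compound 2 to compound 3 (0.04 log units; within the scatter), the first direct comparison of two groups at this one place, and the two compounds cannot be told apart. The 4-nitrophenyl end also cannot be separated from the 3-(trifluoromethoxy)phenyl end, with a 1.4-fold higher number from compound 1 to compound 3 (0.16 log units; within the scatter), so none of the three aryl ends shown stands apart from the others. No evidence at hand bears on why these readings stay so close.

Going by these compounds, whether a carboxylic acid or a dimethylamino group on this aromatic carbon would also stay within the scatter remains open. So does whether a change away from the aryl end, such as a longer chain in place of the double-bonded chain, would move the number.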